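Replacing 3,4-difluorophenyl with 2-methylphenyl on the amide-type nitrogen

The source may hold more compounds than are shown below. What is called first, only, known or untested is meant among the compounds shown, and "the series" means these compounds.

Within the data shown here, in a functional assay on MDA-MB-231 cells (Homo sapiens) for cytotoxicity, read by MTT assay, with a stated time of 72 h (on this read-out higher numbers stand for weaker inhibition and lower numbers for stronger inhibition), compound 1 `COc1ccc(NC(=O)CN2CCN(c3nnc(Cc4ccccc4)c4ccccc34)CC2)cc1OC` gives 32200 nM and compound 2 `O=C(CN1CCN(c2nnc(Cc3ccccc3)c3ccccc23)CC1)Nc1ccc(F)c(F)c1` gives 2750 nM as the lower of the two numbers so far. Compound 3 `Cc1ccccc1NC(=O)CN1CCN(c2nnc(Cc3ccccc3)c3ccccc23)CC1` keeps the shared core and carries 2-methylphenyl in place of 3,4-difluorophenyl on an amide-type nitrogen describes the change. Among the measured compounds shown here, only one measured step bears on it: a 12-fold lower number from compound 1 to compound 2 (1.07 log units; beyond the scatter) with 3,4-difluorophenyl in place of 3,4-dimethoxyphenyl at the same place. For the measured compounds named here, that step is large and beyond the scatter, so substantial movement in this assay is plausible here, although no measured compound carries 2-methylphenyl. Going by the values given here, a moderate rise is expected, smaller than the one measured step, and the estimated change is a 2.9-fold higher number from compound 2 to compound 3 (0.46 log units; beyond the scatter) overall. The estimate for compound 3 is 8000 nM within an expected range of 2500 nM to 28000 nM in this series.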

Compound 3, half-maximal inhibitory concentration: 17300 nM
Compound 3: the middle estimate sits 2.2-fold (0.33 log units) below what was measured, and the stated range covers the measured number.
By their numbers in this assay, from the lowest: compound 2; then compounds 3 and 1 (each within the scatter of the next).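

In this assay, moving from 3,4-difluorophenyl to 2-methylphenyl on the amide-type nitrogen gives a 6.3-fold higher number from compound 2 to compound 3 (0.80 log units; beyond the scatter), so the lower number at this place does not carry over to every carbon-only aromatic ring. Among these compounds, the two groups without fluorine cannot be told apart here, with a 1.9-fold lower number from compound 1 to compound 3 (0.27 log units; within the scatter), which leaves 3,4-difluorophenyl as the only one of the three groups that stands apart at this place. No available evidence accounts for this difference.

Compound 3 differs from compound 2 both in losing the two fluorine atoms and in the placement of its substituent, and the compounds shown do not separate these changes. From the compounds shown here alone, it remains open whether plain phenyl or 3,4-dichlorophenyl at this place would fall with compound 2 or with compounds 1 and 3.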